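Chloro for fluoro on the pendant phenyl: a second core

A few compounds are considered here, and "the series" means these few. Any claim that something is new, unique, unknown or untested is made for them only; others in the source may bear on it.

Compound 1 `COc1cc(/C=C2\CN(C)C/C(=C\c3ccc(F)cc3)C2=O)cc(OC)c1OC` gives 7250 nM in a functional assay on HeLa cells (Homo sapiens) for cytotoxicity, read by MTT assay, with a stated time of 24 h; a higher number here means a weaker inhibitor, a lower number a stronger inhibitor. Compound 2 `COc1cc(/C=C2\CN(C)C/C(=C\c3ccc(Cl)cc3)C2=O)cc(OC)c1OC` reaches only the assay limit of > 20000 nM in this assay, as noted under (the limit of > 20000 nM in this assay, at which 1 of the 3 values shown sits). The change chloro in place of fluoro on an aromatic carbon therefore produces an at least 2.7-fold higher number from compound 1 to compound 2 (0.44 log units; beyond the scatter). Compound 3 `CN1C/C(=C\c2ccc(F)cc2)C(=O)/C(=C/c2cccc([N+](=O)[O-])c2)C1` gives 6250 nM in this assay; its value and that of compound 1 lie within the scatter of each other. The difference between the core of compound 3 and the core of compound 1 is not broken down here. Compound 4 `CN1C/C(=C\c2ccc(Cl)cc2)C(=O)/C(=C/c2cccc([N+](=O)[O-])c2)C1` carries the same change as before, (chloro in place of fluoro on an aromatic carbon), at the same place. Resting on the step of an at least 2.7-fold higher number from compound 1 to compound 2 (0.44 log units; beyond the scatter), compound 4 is expected to show a 2.6-fold higher number from compound 3 to compound 4 (0.41 log units; beyond the scatter). Compound 4 is thus estimated at 16000 nM in this assay, between 6000 nM and 40000 nM.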

Compound 4, half-maximal inhibitory concentration: > 20000 nM
Compound 4 ended at the assay's limit (the forecaster's own chance of this, stated with the estimate: 40%); middle value at least 1.2-fold (0.09 log units) from the limit.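

In this assay, the change from 4-fluorophenyl to 4-chlorophenyl on a second core again gives an at least 3.2-fold higher number from compound 3 to compound 4 (0.50 log units; beyond the scatter), so the direction of the step carried over from the core of compound 1 to the core of compound 3. Both chloro compounds reach a limit of the assay, not a measured number: the limit of > 20000 nM in this assay, at which 2 of the 4 values shown sit. The two cores therefore agree in direction, but the size of the step cannot be compared between them: the same change on two cores in this assay, an at least 2.7-fold higher number (0.44 log units; beyond the scatter) from compound 1 to compound 2 and an at least 3.2-fold higher number (0.50 log units; beyond the scatter) from compound 3 to compound 4; the limit leaves it open whether they differ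

As far as these compounds go, the actual values of compound 2 and compound 4 remain open. Also open, from the compounds shown here alone, is how bromo, methoxy or an amine would behave at the same place, on either core.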